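The source may hold more compounds than are shown below. What is called first, only, known or untested is meant among the compounds shown, and "the series" means these compounds.

Compound 1 `CCCCn1nc2ccccc2c1OCC` gives 807 nM in an assay on isolated protein (urine) for inhibition of Myeloperoxidase (Homo sapiens), read by spectrophotometry; a lower number here means a stronger inhibitor, a higher number a weaker inhibitor.
Compound 2 `CCCCCCCCn1nc2ccccc2c1OCC` gives only a limit of the assay in this assay, > 10000 nM.
Compound 3 `CCCCn1[nH]c2ccccc2c1=O` gives 792 nM in this assay.

Compound 1 and compound 2 share a core and differ in one place: butyl in place of hydrogen on a saturated chain carbon, four bonds along the chain from an aromatic nitrogen. That change produced an at least 12-fold higher number from compound 1 to compound 2 (1.09 log units; beyond the scatter). For the measured compounds named here, the value of compound 2 is a limit, not a number, and it is the only such value among the three measured compounds, so the size of that step is known only as a lower bound (the limit of > 10000 nM in this assay, at which 1 of the 3 values shown sits).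

Compound 3 carries a different core; how its core differs from that of compound 1 is not broken down here. The two compounds sit within the scatter of each other in this assay.

Compound 4 `CCCCCCCCn1[nH]c2ccccc2c1=O` is the analogue of compound 3 that bears the same change already seen between compound 1 and compound 2: butyl in place of hydrogen on a saturated chain carbon, four bonds along the chain from an aromatic nitrogen. The place of the change reads the same on both cores, so it is taken as the same change. Going by the values given here, since the one measured example of this change, from compound 1 to compound 2, ran beyond the scatter and ended at the limit of the assay, compound 4 is expected to lose activity by a comparable amount, estimated as a 15-fold higher number from compound 3 to compound 4 (1.18 log units; beyond the scatter). Compound 4 is therefore expected to give about 12000 nM in this assay, with the likely range running from 4000 nM to 40000 nM, and a real chance that only a limit is reported.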

Compound 4, half-maximal inhibitory concentration: > 10000 nM
Compound 4: no number, only a limit; the forecaster's own chance of this, stated with the estimate: 55%; the middle value does not contradict the limit.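

In this assay, butyl in place of hydrogen on a saturated chain carbon, four bonds along the chain from an aromatic nitrogen, gives an at least 12-fold higher number from compound 3 to compound 4 (1.10 log units; beyond the scatter), so the loss of activity seen on the core of compound 1 also appears on the core of compound 3. Set side by side, the two steps read: the same change on two cores in this assay, an at least 12-fold higher number (1.09 log units; beyond the scatter) from compound 1 to compound 2 and an at least 12-fold higher number (1.10 log units; beyond the scatter) from compound 3 to compound 4; the limit leaves it open whether they differ. This shows that the direction of the change, and a size of at least the printed amount, carried over between these two cores, but it does not show that the two steps are equal or how large either one really is, and two cores are too few to establish a rule for the series, as both longer-chain compounds end at a limit rather than a number: the limit of > 10000 nM in this assay, at which 2 of the 4 values shown sit.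

The compounds shown leave open how activity falls away with chain length, and whether a pentyl or hexyl chain in place of the chains of compound 1 and compound 3 would still give a readable number in this assay. They also leave open whether a long chain carrying an amine or a carboxylic acid would behave like the plain chains seen here, on either core.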